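Methyl position on the sulfonyl aryl: compound 1 to compound 3

The source may report more compounds than this note shows. Statements on the series, on what has been measured and on what is new or still open speak of the compounds shown alone.

Measured so far:
compound 1 `Cc1ccc(S(=O)(=O)Nc2ccc3oc(-c4ccccc4)nc3c2)cc1` — > 100000 nM
compound 2 `O=S(=O)(Nc1ccc(-c2nc3ccccc3o2)cc1)c1ccc(F)cc1` — 73000 nM

Both were run in an assay on cells for inhibition of HSP60/HSP10 (Homo sapiens), with a stated time of 60 min; a lower number here means a stronger inhibitor, a higher number a weaker inhibitor. For compound 1 the reported value > 100000 nM is a limit of the assay, not a number (the limit of > 100000 nM in this assay, at which 1 of the 2 values shown sits). Compound 2 gives 73000 nM in this assay, a weak result. Among the compounds with values here, the two measured compounds differ in more than one place, so no single step between them can be read; what the two values show is only that neither is a strong inhibitor.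

Compound 3 `Cc1cccc(S(=O)(=O)Nc2ccc3oc(-c4ccccc4)nc3c2)c1` is the next one to be measured. It differs from compound 1 as follows: 3-methylphenyl in place of 4-methylphenyl on a sulfonyl sulfur. Within the data shown here, nothing among the measured compounds speaks to this change, and the starting point is itself a limit. The expectation is therefore that compound 3 stays about where compound 1 sits, with no step beyond the usual scatter, which as an estimate means a number no higher from compound 1 to compound 3 (the limit leaves the size open). The estimate for compound 3 in this assay is 100000 nM, with a range from 30000 nM to 300000 nM, and a fair chance that only a limit is reported again.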

Compound 3, half-maximal inhibitory concentration: > 100000 nM
Compound 3 gave a limit, no number; the forecaster's own chance of this, stated with the estimate: 60%; the middle value lies on the limit itself.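

No step can be read from compound 1 to compound 3, since both results are limits and not numbers: the limit of > 100000 nM in this assay, at which 2 of the 3 values shown sit. The compounds shown leave open how 3-methylphenyl and 4-methylphenyl on a sulfonyl sulfur compare, and whether either compound has a potency that can be put as a number.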